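A Swap of Aryl Groups on a Shared Core

This account rests on a few compounds, and the source may have more. Where it says the series, first, only, none or still open, it means among the compounds named here.

Of the compounds shown here, three have been measured in an assay on microsomes from liver for inhibition of 3-hydroxy-3-methylglutaryl-coenzyme A reductase (Rattus norvegicus); a higher number here means a weaker inhibitor, a lower number a stronger inhibitor. Compound 1 `CC[C@H](C)C(=O)O[C@H]1C[C@H](O)C=C2C=C[C@H](C)[C@H](CCC(O)C[C@H](O)CC(=O)O)[C@]21C` gives 5 nM, compound 2 `COc1cccc(-c2nc(C(F)(F)F)n(CC[C@@H](O)C[C@@H](O)CC(=O)O)c2-c2ccc(F)cc2)c1` gives 20 nM, and compound 3 `COc1cccc(-c2c(-c3ccc(F)cc3)nc(C(F)(F)F)n2CC[C@@H](O)C[C@@H](O)CC(=O)O)c1` gives 135 nM, the highest of the three numbers; its nearest neighbour is compound 2 and its furthest is compound 1, and both gaps lie beyond the usual scatter of repeat measurements. Compound 4 `Cc1cc(-c2c(-c3ccc(F)cc3)nc(C(F)(F)F)n2CC[C@@H](O)C[C@@H](O)CC(=O)O)cc(C)c1F` differs from compound 3 in a single place: 4-fluoro-3,5-dimethylphenyl in place of 3-methoxyphenyl on an aromatic carbon. Among the measured compounds shown here, no measured pair shows this same change, so the size of the step can only be estimated. The expected step of a 1.7-fold lower number from compound 3 to compound 4 (0.23 log units; within the scatter) is small, toward a lower number, and hardly beyond the scatter. Compound 4 is therefore estimated at 80 nM in this assay, with a range from 25 nM to 300 nM.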

Compound 4, half-maximal inhibitory concentration: 31 nM
The estimate for compound 4 lay 2.6-fold (0.41 log units) above the measured number; low and high end bracket the measured number.
By their numbers in this assay, from the lowest: compound 1; then compounds 2 and 4 (each within the scatter of the next); then compound 3.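

In this assay, the aryl group at this position of the shared core clearly affects the result: 4-fluoro-3,5-dimethylphenyl in place of 3-methoxyphenyl gives a 4.4-fold lower number from compound 3 to compound 4 (0.64 log units; beyond the scatter) in a modest step. Among the compounds shown here, the earlier compounds offered no single-place step, so this is the first direct reading of a change here. Nothing measured here explains the shift.

From the compounds shown here alone, the swap removes the methoxy group and adds fluorine and two methyl groups at once, so their separate shares remain unknown. A simple 3,5-dimethylphenyl or 4-fluorophenyl group at this position would help to separate them.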